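Methoxy for Methyl on a Fused Five-Ring Core

The source may report more compounds than this note shows. Statements on the series, on what has been measured and on what is new or still open speak of the compounds shown alone.

Measured compounds:
compound 1, `CCc1nc2c3ccccc3oc2c2c1c(=O)oc1cc(C)ccc12`, 35.4%
compound 2, `Cc1nc2c3ccccc3oc2c2c1c(=O)oc1cc(Cl)ccc12`, 21.6%

In a functional assay on the whole organism with Rattus norvegicus as the target, with a stated time of 3 h, at a dose of 200 mg/kg (a lower number here means a weaker effect, a higher number a stronger effect of the compound at the dose given), compound 1 gives 35.4%, the higher of the two numbers in hand. Compound 2 gives 21.6% in this assay, a gap beyond the usual scatter; as the two compounds differ in more than one place, only the two values themselves can be compared.

Compound 3, `CCc1nc2c3ccccc3oc2c2c1c(=O)oc1cc(OC)ccc12`, follows from compound 1 by a single change: methoxy in place of methyl on an aromatic carbon. Among the compounds with values here, no measured pair shows what such an exchange does in this assay, so the expected step is small and its direction uncertain. The step expected is a number 5.4 percentage points lower from compound 1 to compound 3 (within the scatter), not beyond the scatter either way. Compound 3 is therefore estimated at 30% in this assay, with a range from 10% to 50%.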

Compound 3, a percentage reported as inhibition, in the whole organism at one dose (the size of the read-out at that dose, not a potency): 35.7%
Estimate against measurement, compound 3: 5.7 percentage points below, within the range that was stated.
By their numbers in this assay, from the lowest: compound 2; then compounds 1 and 3 (each within the scatter of the next).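

Within the data shown here, the exchange gives the first step on the shared core that can be read in one place: at this aromatic carbon, meta to a fused ring and para to a fused ring, methoxy in place of methyl comes to a number 0.3 percentage points higher from compound 1 to compound 3 (within the scatter) in this assay. Methoxy brings an oxygen and a hydrogen-bond acceptor that methyl lacks, yet the read-out at this single dose does not separate the two compounds. Nothing measured here offers an explanation for this result.

From the compounds shown here alone, whether an amine or a carboxylic acid on this carbon would also stay within the scatter remains open. So do the separate contributions of the chlorine and the ring substituent in compound 2, which differs from compound 1 and compound 3 in more than one place.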